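The source may report more compounds than this note shows. Statements on the series, on what has been measured and on what is new or still open speak of the compounds shown alone.

Compound 1, `NC(=O)c1c(NC(=O)c2ccccc2Cl)sc2c1CCN(Cc1ccc([N+](=O)[O-])cc1)C2`, gives 11400 nM in a functional assay on HL-60 cells (Homo sapiens) for antiproliferative activity, with a stated time of 24 h; a higher number here means a weaker inhibitor, a lower number a stronger inhibitor. Compound 2, `NC(=O)c1c(NC(=O)c2ccccc2Cl)sc2c1CCN(C(=S)Nc1cc(C(F)(F)F)cc(C(F)(F)F)c1)C2`, gives 6500 nM in this assay.

For the measured compounds named here, of these two numbers, the one for compound 1 is the higher, but the gap to compound 2 falls within the usual scatter, so the two cannot be told apart. Compound 3, `NC(=O)c1c(NC(=O)c2ccccc2Cl)sc2c1CCN(C(=S)Nc1cccnc1)C2`, has not yet been measured. It differs from compound 1 in one place: a group of 9 heavy atoms (6 carbon, 2 nitrogen, 1 sulfur; one six-membered aromatic ring with 1 hetero atom) in place of a group of 10 heavy atoms (7 carbon, 1 nitrogen, 2 oxygen; one six-membered aromatic ring of carbon only), on an amine nitrogen in a ring. Going by the values given here, no measured pair shows this exact change, so its effect is unknown. Because compound 2, which also carries a thiourea on that ring nitrogen, gives 6500 nM, the step of a 1.4-fold lower number from compound 1 to compound 3 (0.15 log units; within the scatter) is expected to be small, if anything toward a lower number, and not clearly beyond the scatter. Compound 3 is estimated at 8000 nM, in the range 3000 nM to 25000 nM.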

Compound 3, half-maximal inhibitory concentration: 33900 nM
Compound 3: middle estimate off by 4.2-fold (0.63 log units), on the low side; measured number outside the range, above it.
By their numbers in this assay, from the lowest: compounds 2 and 1 (each within the scatter of the next); then compound 3.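

On the amine nitrogen in the ring, replacing the 4-nitrobenzyl group with the thiourea carrying a six-membered aromatic ring with one hetero atom gives a 3.0-fold higher number from compound 1 to compound 3 (0.47 log units; beyond the scatter) in this assay, so this position responds to the group placed on it. Sharing a thiourea does not settle the number: compound 2 gives 6500 nM and compound 3 gives 33900 nM here, so the ring on the thiourea also matters. Nothing measured here explains the step.

From the compounds shown here alone, whether the thiourea link or its ring drives the step stays open. A plain benzyl group or a simple acetyl group on this nitrogen could help separate the two.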